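Fluoro to chloro on the 3-fluorophenyl group of compound 1

A few compounds are considered here, and "the series" means these few. Any claim that something is new, unique, unknown or untested is made for them only; others in the source may bear on it.

Measured compounds:
compound 1, `O=C(O)CCc1ccc(OCc2ncc(-c3cccc(F)c3)o2)cc1`: 1070 nM
compound 2, `O=C(O)CCc1ccc(OCc2ncc(-c3ccccc3)o2)cc1`: 1600 nM

In a functional assay on CHO cells for agonist activity at Free fatty acid receptor 1 (Homo sapiens), read by FLIPR and calcium flux, in the presence of a further agent that is not named here (on this read-out lower numbers stand for an effect already at smaller amounts and higher numbers for an effect only at larger amounts of compound), compound 1 gives 1070 nM, the lowest of the two numbers, but the gap to compound 2 is small: a 1.5-fold higher number from compound 1 to compound 2 (0.17 log units; within the scatter), which is within the scatter. Compound 3, `O=C(O)CCc1ccc(OCc2ncc(-c3cccc(Cl)c3)o2)cc1`, differs from compound 1 in one place: chloro in place of fluoro on an aromatic carbon. Among the compounds with values here, the only measured step that bears on this position is the removal of the fluoro to hydrogen, from compound 1 to compound 2, and it stayed within the scatter. Within the data shown here, no chloro analogue has been measured, so the direction of a chloro for fluoro exchange rests on no data beyond that. Given the small effect of the one known change at this site, compound 3 is expected to sit near compound 1, with a 1.3-fold lower number from compound 1 to compound 3 (0.13 log units; within the scatter), and its estimated value in this assay is 800 nM, in the range 300 nM to 2200 nM.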

Compound 3, half-maximal effective concentration: 47500 nM
Compound 3: the middle estimate sits 59-fold (1.77 log units) below what was measured; the measured number lies above the stated range.
By their numbers in this assay, from the lowest: compounds 1 and 2 (each within the scatter of the next); then compound 3.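

In this assay, chloro in place of fluoro gives a 44-fold higher number from compound 1 to compound 3 (1.65 log units; beyond the scatter) and chloro in place of hydrogen gives a 30-fold higher number from compound 2 to compound 3 (1.47 log units; beyond the scatter) on the same aromatic carbon, whereas hydrogen in place of fluoro gave only a 1.5-fold higher number from compound 1 to compound 2 (0.17 log units; within the scatter) and stayed within the scatter. The position that looked insensitive from compound 1 and compound 2 alone is therefore not indifferent to what it carries: fluoro and hydrogen cannot be told apart there, while chloro stands well apart from both. Nothing available explains why this single exchange has so large an effect.

As far as these compounds go, whether the loss is particular to chloro or extends to other groups on this carbon, such as bromo, methyl or methoxy, remains open. So does whether chloro on another carbon of the same ring would behave in the same way.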